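The source may hold more compounds than are shown below. What is called first, only, known or untested is meant among the compounds shown, and "the series" means these compounds.

Compound 3, with structure `O=C1COc2ccc(-c3[nH]c(-c4ccccc4)nc3-c3ccccc3)cc2N1`, shares its core with compound 1, structure `O=C1COc2ccc(-c3[nH]c(-c4ccc(F)cc4)nc3-c3ccccc3)cc2N1`, and compound 2, structure `O=C1COc2ccc(-c3[nH]c(-c4c[nH]c5ncccc45)nc3-c3ccccc3)cc2N1`. In a functional assay on DLD-1 cells (Homo sapiens) for cytotoxicity, read by colorimetric assay and MTT assay, with a stated time of 3 days, tested at 1 uM (a lower number here means a stronger effect, a higher number a weaker effect of the compound at the concentration tested), compound 3 gives 98.2%, the highest of the three numbers shown, though its neighbours lie close: compound 2 gives 97.7% and compound 1 gives 94.8%. The three measured steps all fall on the same position of the core. The change a number 3.4 percentage points higher from compound 1 to compound 3 (within the scatter) is within the scatter, as is a number 2.9 percentage points higher from compound 1 to compound 2 (within the scatter) and a number 0.5 percentage points higher from compound 2 to compound 3 (within the scatter). None of the three groups tried so far at this position moves the read-out beyond the usual scatter.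

Compound 4, structure `O=C1COc2ccc(-c3[nH]c(-c4ccc(Cl)cc4Cl)nc3-c3ccccc3)cc2N1`, differs from compound 3 by 2,4-dichlorophenyl in place of phenyl on an aromatic carbon. All three earlier steps bear on this change, since each exchanges the group at this same place, and each was within the scatter. On that basis no step beyond the scatter is expected in this assay from compound 3 to compound 4; the expected change is a number 2.2 percentage points lower from compound 3 to compound 4 (within the scatter). Compound 4 is therefore estimated at 96% in this assay, with a range from 86% to 103%.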

Compound 4, a percentage reported as activity, at one concentration (the size of the read-out at that concentration, not a potency): 97.8%
Compound 4: the middle estimate sits 1.8 percentage points below what was measured, within the range that was stated.
By their numbers in this assay, from the lowest: compounds 1, 2, 4 and 3 (each within the scatter of the next).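

The step of a number 0.4 percentage points lower from compound 3 to compound 4 (within the scatter) shows that in this assay the read-out at this place, on an aromatic carbon between two ring nitrogen atoms, also holds when 2,4-dichlorophenyl, a larger group with substituents on the aromatic ring, enters in place of phenyl. The comparisons with the other two groups point the same way: the step of a number 0.1 percentage points higher from compound 2 to compound 4 (within the scatter) and the step of a number 3 percentage points higher from compound 1 to compound 4 (within the scatter) leave 2,4-dichlorophenyl inseparable from both, so the four groups now tried at this place cannot be ranked against one another in this assay. Nothing available here explains this flat result.

On these data alone, all four groups at this place are built from aromatic rings, so it stays open whether an amine, a carboxylic acid or a longer alkyl chain there would move the read-out beyond the scatter. As far as these compounds go, it also stays open whether a change to the phenyl group or the large group on the other two ring atoms would do so, since the shared core carries both unchanged in all four compounds.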